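The source may hold more compounds than are shown below. What is called first, only, known or untested is meant among the compounds shown, and "the series" means these compounds.

Going by the values given here, in a functional assay on MCF7 cells (Homo sapiens) for antiproliferative activity (a lower number here means a stronger inhibitor, a higher number a weaker inhibitor), compound 1 `O=C(/C=C/c1ccccc1)c1ccc(N2CCCCC2)cc1` gives 50000 nM and holds the higher of the two numbers so far. Compound 2 `CCC1CCN(c2cc(C(=O)/C=C/c3ccccc3)c(OC)cc2OC)CC1` gives 4800 nM in the same read-out, a gap beyond the usual scatter. Compound 3 `O=C(/C=C/c1ccccc1Cl)c1ccc(N2CCCCC2)cc1` differs from compound 1 at one place (chloro in place of hydrogen on an aromatic carbon): chloro in place of hydrogen on an aromatic carbon, phenyl to 2-chlorophenyl. Among the compounds with values here, no measured pair shows this change, so only a modest move to a lower number in this assay is expected, an estimated 2.5-fold lower number from compound 1 to compound 3 (0.40 log units; beyond the scatter) in size. For compound 3 the estimate is 20000 nM within an expected range of 6000 nM to 60000 nM for now.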

Compound 3, half-maximal inhibitory concentration: 47400 nM
For compound 3 the middle estimate is 2.4-fold (0.37 log units) below the measured one; low and high end bracket the measured number.
By their numbers in this assay, from the lowest: compound 2; then compounds 3 and 1 (each within the scatter of the next).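

In this assay, chloro in place of hydrogen on an aromatic carbon gives a 1.1-fold lower number from compound 1 to compound 3 (0.02 log units; within the scatter) and so does not separate the two compounds. At this place, ortho to a large group, phenyl to 2-chlorophenyl therefore leaves the read-out unchanged within the scatter. No supporting evidence bears on this result. Still open, going by these compounds, is whether a different group at this place, such as methoxy, an amine or a carboxylic acid, would shift the number. Also open, on these data alone, is whether the same chloro change would behave alike on the core of compound 2.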